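Swapping the Aryl Group on Compound 2

A few compounds are considered here, and "the series" means these few. Any claim that something is new, unique, unknown or untested is made for them only; others in the source may bear on it.

For the measured compounds named here, in an ADME assay on Vero cells (Chlorocebus sabaeus) for cytotoxicity, read by sulforhodamine B assay, with a stated time of 3 days (on this read-out higher numbers stand for lower toxicity in this test and lower numbers for higher toxicity in this test), compound 2 `CC1=C(C(=O)Nc2ccc(Cl)cc2)C(c2cccc(Cl)c2)C(C(=O)Nc2ccc(Cl)cc2)=C(C)N1` gives 12 ug/mL, the lower of the two numbers so far, while compound 1 `CC1=C(C(=O)Nc2ccc(Cl)cc2)C(c2cccc([N+](=O)[O-])c2)C(C(=O)Nc2ccc(Cl)cc2)=C(C)N1` gives 26 ug/mL. The next structure, compound 3 `CC1=C(C(=O)Nc2ccc(Cl)cc2)C(c2ccc(N(C)C)cc2)C(C(=O)Nc2ccc(Cl)cc2)=C(C)N1`, carries 4-(dimethylamino)phenyl in place of 3-chlorophenyl on a saturated ring carbon. Going by the values given here, only one measured step bears on this change: a 2.2-fold lower number from compound 1 to compound 2 (0.34 log units; beyond the scatter), a modest step for chloro in place of nitro on an aromatic carbon. Among the compounds with values here, that step altered the aromatic group at this same saturated ring carbon, but no measured compound carries a dimethylamino group, so it offers only a rough guide to size. The expected change is a 1.4-fold higher number from compound 2 to compound 3 (0.15 log units; within the scatter), which leans upward without a clear move beyond the scatter in this assay. For compound 3 the estimated value is 17 ug/mL, with an expected range from 6 ug/mL to 48 ug/mL.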

Compound 3, half-maximal cytotoxic concentration: 155 ug/mL
The estimate for compound 3 lay 9.1-fold (0.96 log units) below the measured number; measured number above the stated range.
By their numbers in this assay, from the lowest: compound 2; then compound 1; then compound 3.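

In this assay the aryl group on the saturated ring carbon can shift the number much further than the first pair suggested, as the large step with 4-(dimethylamino)phenyl in place of 3-chlorophenyl shows (a 13-fold higher number from compound 2 to compound 3 (1.11 log units; beyond the scatter)). The same group also stands clear of 3-nitrophenyl (a 6.0-fold higher number from compound 1 to compound 3 (0.78 log units; beyond the scatter)), so compound 3 carries the highest number of the three, which here stands for the lowest toxicity in this test. Nothing given here accounts for this rise.

Since both the substituent and its ring position differ between these aryl groups, the compounds shown do not separate the two. They also leave open how 4-aminophenyl or 4-methoxyphenyl would behave at this carbon, and whether the dimethylamino group itself is needed.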